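This account rests on a few compounds, and the source may have more. Where it says the series, first, only, none or still open, it means among the compounds named here.

Working notes on the sigma series.

Compound 1 `CN(C)CCCCCCCOc1ccc2oc(-c3ccccc3)cc(=O)c2c1` is the reference point. In an assay on isolated protein (Cavia porcellus) with Sigma non-opioid intracellular receptor 1 (Homo sapiens) as the target, read by radioligand binding (on this read-out higher numbers stand for weaker inhibition and lower numbers for stronger inhibition), compound 1 gives 165 nM. Among the measured compounds shown here, compound 2 `O=c1cc(-c2ccccc2)oc2ccc(OCCCCCCN3CCCC(O)C3)cc12` is the only other measured member; in this assay compound 2 gives 86 nM. On the two numbers shown, compound 1 carries the upper one, but its sole neighbour is compound 2 and the step of a 1.9-fold lower number from compound 1 to compound 2 (0.28 log units; within the scatter) falls within the scatter, so the two cannot be told apart on these data.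

Compound 3 `CCN(CC)CCCCCCOc1ccc2oc(-c3ccccc3)cc(=O)c2c1` is the next candidate. It differs from compound 1 by diethylamino in place of (dimethylamino)methyl on a saturated chain carbon, six bonds along the chain from an oxygen on an aromatic ring.

For the measured compounds named here, only one measured step bears on this change: the step from compound 1 to compound 2 also alters the amine end of the chain, six bonds along from the aromatic oxygen, and gave a 1.9-fold lower number from compound 1 to compound 2 (0.28 log units; within the scatter), within the scatter. Replacing one small amine terminus by another therefore gives no reason to expect a step beyond the scatter, in either direction; the expected change is a 1.1-fold lower number from compound 1 to compound 3 (0.04 log units; within the scatter). Compound 3 is expected to come out near 150 nM, with a range of 60 nM to 400 nM.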

Compound 3, half-maximal inhibitory concentration: 91 nM
Compound 3: the middle estimate sits 1.6-fold (0.22 log units) above what was measured; the range from low to high includes it.
By their numbers in this assay, from the lowest: compounds 2, 3 and 1 (each within the scatter of the next).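

In this assay, the change to diethylamino on a saturated chain carbon, six bonds along the chain from an oxygen on an aromatic ring, gives a 1.8-fold lower number from compound 1 to compound 3 (0.26 log units; within the scatter) and so adds a second amine terminus that cannot be told apart from (dimethylamino)methyl on these data. The comparison with the ring-bearing terminus gives a 1.1-fold higher number from compound 2 to compound 3 (0.02 log units; within the scatter) and shows that diethylamino, which has no ring, cannot be told apart from 3-hydroxypiperidin-1-yl either, so all three termini so far fall within the scatter of one another at this position. No supporting data bear on this result.

The compounds shown leave open whether any replacement at this end of the chain can move the number beyond the scatter, for example a morpholin-4-yl or piperazin-1-yl terminus, or a carboxylic acid in place of the amine. They also leave open how a shorter or longer chain would read with the diethylamino terminus held fixed on the shared core.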